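This account rests on a few compounds, and the source may have more. Where it says the series, first, only, none or still open, it means among the compounds named here.

Working notes on the series. Compound 1 `Cc1cc(Cl)cc(-c2c(C)nn(-c3nc(-c4ccc(Cl)c(Cl)c4)c(SC(C)C)s3)c2C(=O)O)c1` gives 663 nM in a functional assay on BJAB cells (Homo sapiens) for antiproliferative activity, with a stated time of 4 days; on this read-out higher numbers stand for an effect only at larger amounts of compound and lower numbers for an effect already at smaller amounts; compound 2 `Cc1cc(C#N)cc(-c2c(C)nn(-c3nc(-c4ccc(Cl)c(Cl)c4)c(SC(C)C)s3)c2C(=O)O)c1` gives 4800 nM and compound 3 `Cc1nn(-c2nc(-c3ccc(Cl)c(Cl)c3)c(SC(C)C)s2)c(C(=O)O)c1-c1cnccn1` gives 14000 nM, the highest number of the three. The two changes at the same aromatic carbon are both known: a 21-fold higher number from compound 1 to compound 3 (1.32 log units; beyond the scatter) and a 2.9-fold higher number from compound 2 to compound 3 (0.46 log units; beyond the scatter), with a 7.2-fold higher number from compound 1 to compound 2 (0.86 log units; beyond the scatter) in between. Compound 4 `Cc1nn(-c2nc(-c3ccc(Cl)c(Cl)c3)c(SC(C)C)s2)c(C(=O)O)c1-c1ccccc1C(F)(F)F` reverses this kind of change: 2-(trifluoromethyl)phenyl in place of pyrazin-2-yl on an aromatic carbon. Since a phenyl with two small substituents gave the lower numbers for compound 1 and compound 2, a step downward from compound 3 is expected, of the size seen in a 2.9-fold higher number from compound 2 to compound 3 (0.46 log units; beyond the scatter) or somewhat more, as a 9.3-fold lower number from compound 3 to compound 4 (0.97 log units; beyond the scatter). Compound 4 is therefore estimated at 1500 nM, within 400 nM to 6000 nM.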

Compound 4, half-maximal effective concentration: 5200 nM
Estimate against measurement, compound 4: 3.5-fold (0.54 log units) below; the range from low to high includes it.
By their numbers in this assay, from the lowest: compound 1; then compounds 2 and 4 (each within the scatter of the next); then compound 3.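

At this aromatic carbon, a carbon-only ring with a single substituent, 2-(trifluoromethyl)phenyl, also gives a lower number than pyrazin-2-yl (a 2.7-fold lower number from compound 3 to compound 4 (0.43 log units; beyond the scatter)). It stands level with 3-cyano-5-methylphenyl (a 1.1-fold higher number from compound 2 to compound 4 (0.03 log units; within the scatter)) but well short of 3-chloro-5-methylphenyl (a 7.8-fold higher number from compound 1 to compound 4 (0.89 log units; beyond the scatter)), so a carbon-only ring alone does not bring back the number of compound 1. No measurement available here accounts for these differences. The compounds shown leave open how far the place of a substituent on the phenyl matters apart from its identity. Also open, from the compounds shown here alone, is where a phenyl carrying an amine or a methoxy group would fall.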